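Dropping the Methoxy Group from an Anilino Side Chain

A few compounds are considered here, and "the series" means these few. Any claim that something is new, unique, unknown or untested is made for them only; others in the source may bear on it.

Compound 1 `COc1ccc(Nc2n[n+]([O-])c3ccccc3[n+]2[O-])cc1` carries a methoxy group at the far end of an anilino side chain on the shared core. For the measured compounds named here, in a functional assay on HL-60 cells (Homo sapiens) for cytotoxicity, read by MTT assay, with a stated time of 48 h (a higher number here means a weaker inhibitor, a lower number a stronger inhibitor), compound 1 gives 900 nM, and this is the only genuine number in the set so far. Compound 2 `CCN(CC)c1n[n+]([O-])c2ccccc2[n+]1[O-]` puts a diethylamino group on the same core instead of the anilino chain. In this assay compound 2 reaches only a limit of the assay, > 49000 nM. So of the two values shown, one is a true measurement for compound 1 and the other is the limit of > 49000 nM in this assay, at which 1 of the 2 values shown sits, which means no step between the two can be sized.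

Compound 3 `[O-][n+]1nc(Nc2ccccc2)[n+]([O-])c2ccccc21` differs from compound 1 in a single place: hydrogen in place of methoxy on an aromatic carbon. Going by the values given here, no measured pair in this set shows what such a change does, so the expectation rests on the change being a small one. The expected step is a 1.8-fold higher number from compound 1 to compound 3 (0.25 log units; within the scatter), a modest shift toward a weaker inhibitor, of a size not far beyond the usual scatter. In this assay compound 3 is therefore estimated at 1600 nM, with a plausible range from 450 nM to 6000 nM.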

Compound 3, half-maximal inhibitory concentration: 2900 nM
Beside the measured number, compound 3's estimate is 1.8-fold (0.26 log units) below it, and the stated range covers the measured number.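

In this assay, for the compounds shown here, replacing methoxy with hydrogen on the aromatic carbon para to a large group gives a 3.2-fold higher number from compound 1 to compound 3 (0.51 log units; beyond the scatter), and this is the first step in the set that can be sized. It shows that this position responds to the change, but that the loss is modest: compound 3, which carries only hydrogen there, still gives a true number, 2900 nM, rather than a limit of the assay. Nothing measured here bears on why the number moves with this change.

With only methoxy and hydrogen shown at this position, it remains open whether a hydroxyl group, a fluorine atom, an amine or a longer chain such as ethoxy would give a number closer to that of compound 1, closer to that of compound 3, or outside both. Going by these compounds alone, compound 2 gives > 49000 nM, which is a limit of the assay and not a number, so no step involving it can be read.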